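The compounds below may be only part of what the source reports. "The series", "measured", "known", "first", "only" and "open" are said of these compounds alone.

Of the compounds shown here, three built on one shared core have been measured in an assay on HEK293 cells for inhibition of solute carrier family 22 member 12 (Homo sapiens), read by scintillation counting, with a stated time of 12 min; on this read-out higher numbers stand for weaker inhibition and lower numbers for stronger inhibition. Compound 1 `O=C(O)C1(Sc2ccnc3ccncc23)CCC1` carries nothing at the position of interest and gives 1930 nM. Compound 2 `N#CCCc1ccc2nccc(SC3(C(=O)O)CCC3)c2c1` carries a 2-cyanoethyl group there and gives 2760 nM, the highest of the three numbers shown, although its gap to compound 1 lies within the scatter, so the two cannot be told apart. Compound 3 `O=C(O)C1(Sc2ccnc3ccc(-c4cccc(C(F)(F)F)c4)cc23)CCC1` carries a phenyl bearing a trifluoromethyl group at that position and gives 359 nM, a number beyond the scatter below compound 2.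

Compound 4 `O=C(O)C1(Sc2ccnc3ccc(-c4ccc(F)cc4)cc23)CCC1` differs from compound 2 in one place: 4-fluorophenyl in place of 2-cyanoethyl on an aromatic carbon. Within the data shown here, since compound 3 with an aromatic ring at this position gives 359 nM, a step toward stronger inhibition, beyond the scatter, is expected from compound 2 to compound 4, though only one aryl example supports this. Compound 4 is thus expected to give 550 nM, with a range of 200 nM to 1500 nM. This estimate means an expected step of a 5.0-fold lower number from compound 2 to compound 4 (0.70 log units; beyond the scatter).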

Compound 4, half-maximal inhibitory concentration: 159 nM
Compound 4: the middle estimate sits 3.5-fold (0.54 log units) above what was measured, outside the stated range (below it).
By their numbers in this assay, from the lowest: compound 4; then compound 3; then compounds 1 and 2 (each within the scatter of the next).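

In this assay, putting 4-fluorophenyl in place of 2-cyanoethyl gives a 17-fold lower number from compound 2 to compound 4 (1.24 log units; beyond the scatter), so a single change at this position can shift inhibition by a large amount. Compound 3 gives 359 nM and compound 4 gives 159 nM, so there are now two compounds with a substituted phenyl ring at this position, and both have lower numbers than compound 2. No measurement shown here explains why the 4-fluorophenyl group gives the lower number.

As far as these compounds go, it remains open whether the aromatic ring itself matters or whether a saturated ring such as cyclohexyl would do equally well. A plain phenyl ring with no substituent would also help show what the fluorine and the trifluoromethyl group each contribute.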